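The source may report more compounds than this note shows. Statements on the series, on what has been measured and on what is new or still open speak of the compounds shown alone.

Compound 1 `O=C(O)CCn1c(=O)oc2cc(Cl)c(Cl)cc21` carries two chlorine atoms on its shared core and a short acid chain. In a physicochemical assay for permeability, using PAMPA (a lower number here means that the compound crosses the layer more slowly, a higher number that the compound crosses the layer faster), compound 1 gives 24 nm/s, the lowest of the two plain numbers recorded. Compound 3 `C[C@@H](Oc1cc2oc(=O)n(CCC(=O)O)c2cc1Cl)c1ccc(Cl)cn1` gives 60 nm/s in this assay, a higher number that lies beyond the usual scatter. Compound 2 `C[C@@H](Oc1cc2oc(=O)n(CCC(=O)O)c2cc1Cl)c1cccnn1` sits at the lower limit of this assay, reporting < 3 nm/s, which is a limit and not a number. Within the data shown here, the one measured step between these compounds, an at least 20-fold higher number from compound 2 to compound 3 (1.30 log units; beyond the scatter), is large; it shows how strongly the choice of the aromatic ring on the ether-bearing carbon can move the reading, with the limit of < 3 nm/s in this assay, at which 1 of the 3 values shown sits, marking the floor reached by compound 2.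

Compound 4 `C[C@@H](Oc1cc2oc(=O)n(CCC(=O)O)c2cc1Cl)c1ncco1` is now to be measured in this assay. Relative to compound 1 the change is a group of 8 heavy atoms (5 carbon, 1 nitrogen, 2 oxygen; one five-membered aromatic ring with 2 hetero atoms) in place of one chlorine atom, on an aromatic carbon. Among the measured compounds shown here, no measured step starts from compound 1, so the expectation rests on compounds 2 and 3, whose rings bracket the new five-membered ring. A modest step, a 1.6-fold lower number from compound 1 to compound 4 (0.20 log units; within the scatter), is expected. Compound 4 is estimated at 15 nm/s, with a range from 4 nm/s to 45 nm/s.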

Compound 4, apparent permeability: < 3 nm/s
Compound 4: a limit, no number; the forecaster's own chance of this, stated with the estimate: 15%; middle value at least 5.0-fold (0.69 log units) from the limit.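

Compound 4 ends at a limit of this assay and not at a number, which makes the 1,3-oxazol-2-yl ring the second ring on the ether-bearing carbon to reach this floor: the limit of < 3 nm/s in this assay, at which 2 of the 4 values shown sit.

With only the ring on that carbon changed, the reading shows an at least 20-fold lower number from compound 3 to compound 4 (1.30 log units; beyond the scatter), which leaves 5-chloropyridin-2-yl as the only one of the three rings shown there to give a plain number. On the aromatic carbon that carries a chloro group in compound 1, the larger group gives an at least 8.0-fold lower number from compound 1 to compound 4 (0.90 log units; beyond the scatter).

Compound 2 and compound 4 both stand at the limit, and the step between them cannot be read, leaving their order unknown. Also open, as far as these compounds go, is whether a plain phenyl ring on the ether-bearing carbon would give a number or would stay at the limit.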